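A few compounds are considered here, and "the series" means these few. Any claim that something is new, unique, unknown or untested is made for them only; others in the source may bear on it.

Measured so far in a functional assay on HCT-8 cells (Homo sapiens) for cytotoxicity, read by MTT assay, with a stated time of 24 h; a higher number here means a weaker inhibitor, a lower number a stronger inhibitor:
Compound 1 `CCOC(=O)c1cn(CCCc2ccccc2)c2cc(Cl)ccc2c1=O` gives 17000 nM.
Compound 2 `C=CCn1cc(C(=O)OCC)c(=O)c2ccc(Cl)cc21` gives 45200 nM.
Compound 3 `CCCCn1cc(C(=O)OCC)c(=O)c2ccc(Cl)cc21` gives only a limit of the assay, > 50000 nM.

Compound 3 thus sits at the limit described in the limit of > 50000 nM in this assay, at which 1 of the 3 values shown sits; its place among the three is known only as the higher end, not as a fixed number. The step under consideration leads to compound 4 `CCOC(=O)c1cn(Cc2ccccc2)c2cc(Cl)ccc2c1=O`, still to be measured in this assay. The change is phenyl in place of propyl on a saturated chain carbon bound to an aromatic nitrogen. Among the measured compounds shown here, two measured steps bear on it. an at least 2.9-fold higher number from compound 1 to compound 3 (0.46 log units; beyond the scatter) is a change of the same kind in the opposite direction, phenyl against a small alkyl group, and gave at least a modest rise. a 2.7-fold higher number from compound 1 to compound 2 (0.42 log units; beyond the scatter) and an at least 1.1-fold higher number from compound 2 to compound 3 (0.04 log units; that floor lies within the scatter) show that the short alkyl and alkenyl chains sit at the higher numbers. A lower number is therefore expected for compound 4, roughly the reverse of that rise: the estimated step is an at least 2.0-fold lower number from compound 3 to compound 4 (0.30 log units; that floor lies within the scatter). Compound 4 is expected near 25000 nM, within 10000 nM to 60000 nM.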

Compound 4, half-maximal inhibitory concentration: 27400 nM
The estimate for compound 4 lay 1.1-fold (0.04 log units) below the measured number, and the stated range covers the measured number.
By their numbers in this assay, from the lowest: compounds 1, 4 and 2 (each within the scatter of the next, the first and the last beyond it). At a limit, above all of these: compound 3.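

In this assay, among the compounds shown here, the phenethyl to phenyl change at this carbon gives no step that can be told from the scatter, a 1.6-fold higher number from compound 1 to compound 4 (0.21 log units; within the scatter), and the same holds for the vinyl to phenyl change, a 1.6-fold lower number from compound 2 to compound 4 (0.22 log units; within the scatter), so the phenyl compound cannot be separated from either neighbour, even though the step between those two lies beyond the scatter, a 2.7-fold higher number from compound 1 to compound 2 (0.42 log units; beyond the scatter). The propyl to phenyl change gives only a floor, an at least 1.8-fold lower number from compound 3 to compound 4 (0.26 log units; that floor lies within the scatter), and that floor lies within the scatter, so a real step is neither shown nor excluded. Compound 3 stands at a limit of the assay, not at a number: the limit of > 50000 nM in this assay, at which 1 of the 4 values shown sits.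

Still open, on these data alone, is whether an amine or a carboxylic acid at the end of the chain would move the number at this position. Also open, as far as these compounds go, is how a longer chain carrying the phenyl ring would read against compound 1.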